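A few compounds are considered here, and "the series" means these few. Any claim that something is new, unique, unknown or untested is made for them only; others in the source may bear on it.

In a functional assay on MCF7 cells (Homo sapiens) for inhibition, read by sulforhodamine B assay (a lower number here means a stronger inhibitor, a higher number a weaker inhibitor), compound 1 `O=C1C=C(Nc2cccc(F)c2)C(=O)c2c1nc1n2[C@H]2OC[C@@H](O)[C@H]2OC1` gives 5500 nM, the highest of the two numbers recorded. Compound 2 `COc1ccc(NC2=CC(=O)c3c(nc4n3[C@H]3OC[C@@H](O)[C@H]3OC4)C2=O)cc1` gives 4470 nM, a value that lies within the scatter of compound 1. Compound 3 `CCOc1ccc(NC2=CC(=O)c3c(nc4n3[C@H]3OC[C@@H](O)[C@H]3OC4)C2=O)cc1` returns only a limit, > 4000 nM, which is the limit of > 4000 nM in this assay, at which 1 of the 3 values shown sits. Within the data shown here, the single step between measured neighbours, a step that the limit leaves unreadable from compound 2 to compound 3, therefore cannot be sized. Compound 4 `O=C1C=C(Nc2ccc(I)cc2)C(=O)c2c1nc1n2[C@H]2OC[C@@H](O)[C@H]2OC1` differs from compound 1 by 4-iodophenyl in place of 3-fluorophenyl on an amine nitrogen. Among the measured compounds shown here, no measured step bears on an exchange of the group on the amine nitrogen, so no change beyond the scatter is expected from it. Compound 4 is thus estimated to give about 5000 nM, between 1500 nM and 16000 nM. That amounts to an expected step of a 1.1-fold lower number from compound 1 to compound 4 (0.04 log units; within the scatter).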

Compound 4, half-maximal inhibitory concentration: 2230 nM
The estimate for compound 4 lay 2.2-fold (0.35 log units) above the measured number; measured number inside the range.
By their numbers in this assay, from the lowest: compounds 4, 2 and 1 (each within the scatter of the next, the first and the last beyond it).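

Among these compounds, the group on the amine nitrogen does move the number in this assay: with 4-iodophenyl in place of 3-fluorophenyl there is a 2.5-fold lower number from compound 1 to compound 4 (0.39 log units; beyond the scatter), the first readable step at this position. The exchange alters the halogen and its place on the ring at once, so this single step cannot assign the change to either. Nothing measured here bears on what lies behind this step. On these data alone, whether 3-iodophenyl or 4-fluorophenyl would match compound 4 or compound 1 stays open, as does the outcome with a cyclohexyl group on the amine nitrogen.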